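Trifluorophenyl Aniline Variant of Quinazoline Sulfonamide Series

A few compounds are considered here, and "the series" means these few. Any claim that something is new, unique, unknown or untested is made for them only; others in the source may bear on it.

Measured so far in a functional assay on A-431 cells (Homo sapiens) for antiproliferative activity, read by MTT assay, with a stated time of 72 h; on this read-out lower numbers stand for stronger inhibition and higher numbers for weaker inhibition:
- compound 1 `COc1cc2ncnc(Nc3ccc(Cl)c(C(F)(F)F)c3)c2cc1OCCCCC(=O)Nc1ccc(S(N)(=O)=O)cc1` gives 3910 nM
- compound 2 `C#Cc1cccc(Nc2ncnc3cc(OC)c(OCCCCC(=O)Nc4ccc(S(N)(=O)=O)cc4)cc23)c1` gives 17700 nM
- compound 3 `COc1cc2ncnc(Nc3ccc(F)c(Br)c3)c2cc1OCCCCC(=O)Nc1ccc(S(N)(=O)=O)cc1` gives 8020 nM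

Compound 3 sits second highest of these three numbers, beyond the scatter from both neighbours: a 2.1-fold higher number from compound 1 to compound 3 (0.31 log units; beyond the scatter) and a 2.2-fold lower number from compound 2 to compound 3 (0.34 log units; beyond the scatter). Compound 4 `COc1cc2ncnc(Nc3cc(F)c(F)c(F)c3)c2cc1OCCCCC(=O)Nc1ccc(S(N)(=O)=O)cc1` differs from compound 3 only at the same position: 3,4,5-trifluorophenyl in place of 3-bromo-4-fluorophenyl on a nitrogen on an aromatic ring. All three known steps exchange the group on this nitrogen and each moved this assay by a modest amount, so a modest shift is expected here too, most likely toward a higher number. Compound 4 is therefore estimated at 12000 nM, within 4000 nM to 36000 nM, a step of a 1.5-fold higher number from compound 3 to compound 4 (0.18 log units; within the scatter).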

Compound 4, half-maximal inhibitory concentration: 23400 nM
Beside the measured number, compound 4's estimate is 2.0-fold (0.29 log units) below it, and the stated range covers the measured number.
By their numbers in this assay, from the lowest: compound 1; then compound 3; then compounds 2 and 4 (each within the scatter of the next).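

In this assay, the 3,4,5-trifluorophenyl group on this nitrogen is clearly weaker than the two groups carrying chlorine or bromine, with a 2.9-fold higher number from compound 3 to compound 4 (0.47 log units; beyond the scatter) and a 6.0-fold higher number from compound 1 to compound 4 (0.78 log units; beyond the scatter). Against the 3-ethynylphenyl group the step is a 1.3-fold higher number from compound 2 to compound 4 (0.12 log units; within the scatter), so these two differently built groups cannot be told apart here. Nothing available explains why the three fluorines cost activity. Still open, on these data alone, is how a plain phenyl ring or a 3-chloro-4-fluorophenyl group would behave on this nitrogen, and whether an amine on the ring would change the picture.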